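Swapping the aryl ester of a diacylated core

This account rests on a few compounds, and the source may have more. Where it says the series, first, only, none or still open, it means among the compounds named here.

Measured compounds:
compound 1, `CC(=O)Oc1ccccc1C(=O)O[C@H]1CO[C@H]2[C@@H]1OC[C@H]2OC(=O)c1cccc(C)c1`: 0.0203 h
compound 2, `CC(=O)Oc1ccccc1C(=O)O[C@H]1CO[C@H]2[C@@H]1OC[C@H]2OC(=O)c1ccccc1OC(=O)c1ccccc1`: 0.0722 h

Both compounds were examined in an ADME assay on a cell-free system (plasma, Homo sapiens) for metabolic stability, with Plasma (Rattus norvegicus) as the target, read by HPLC, at pH 7.4; a lower number here means that the compound disappears faster, a higher number that the compound lasts longer. Compound 1 gives the lowest of the two numbers, 0.0203 h. Within the data shown here, compound 2, the only other compound measured, gives 0.0722 h, a higher number that lies beyond the usual scatter. Among the measured compounds shown here, no single-point step between these two has been worked out, so the pair only shows that compound 2 lasts longer than compound 1.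

Compound 3, `CC(=O)Oc1ccccc1C(=O)O[C@H]1CO[C@H]2[C@@H]1OC[C@H]2OC(=O)c1cnoc1C`, is not yet measured. It differs from compound 1 in one place: 5-methyl-1,2-oxazol-4-yl in place of 3-methylphenyl on a carbonyl carbon. The change sits on a carbonyl carbon whose other neighbours are an oxygen next to a carbonyl group; the acetylsalicyloyl part of the shared core stays untouched.

Nothing measured here tells how an aromatic five-membered ring with two hetero atoms behaves in this assay compared with a six-membered ring of carbon only, so no direction can be drawn from the data. The step of a 1.1-fold higher number from compound 1 to compound 3 (0.03 log units; within the scatter) is expected to be small, within the scatter. Compound 3 is estimated at 0.022 h, with a range from 0.008 h to 0.06 h.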

Compound 3, half-life: 0.001 h
Estimate against measurement, compound 3: 22-fold (1.34 log units) above; measured number outside the range, below it.
By their numbers in this assay, from the lowest: compound 3; then compound 1; then compound 2.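

In this assay, exchanging 3-methylphenyl for 5-methyl-1,2-oxazol-4-yl on a carbonyl carbon gives a 20-fold lower number from compound 1 to compound 3 (1.31 log units; beyond the scatter), a large step that lies well beyond the scatter. The earlier compounds shown here offered no readable step, and this one shows that the group at this place is not a passive part of the molecule: with the shared core unchanged, exchanging this one aromatic ring is enough to make the compound disappear much faster. Among these compounds, nothing available explains why a single exchange at this place moves the number so far.

The compounds shown leave open whether the fall belongs to the five-membered ring with its two hetero atoms as a whole or to how its methyl group and hetero atoms are arranged on it, and a single step cannot separate these. They also leave open whether a pyridinyl or a thiophenyl group on the same carbonyl carbon would give a number closer to that of compound 1 or to that of compound 3.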